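A few compounds are considered here, and "the series" means these few. Any claim that something is new, unique, unknown or untested is made for them only; others in the source may bear on it.

The three measured compounds share one core. Compound 1 `c1ccc2c(c1)CC2CN1CCN(c2cccc3c2OCCO3)CC1` gives 0.7 mg/kg in an assay for activation of Adrenergic receptor alpha-1 (Rattus norvegicus); on this read-out lower numbers stand for an effect already at smaller amounts and higher numbers for an effect only at larger amounts of compound. Compound 2 `c1ccc2c(c1)CCC2CN1CCN(c2cccc3c2OCCO3)CC1` gives 5 mg/kg in this assay, and compound 3 `c1ccc2c(c1)CCC2CCN1CCN(c2cccc3c2OCCO3)CC1` gives 4.01 mg/kg in this assay. Compound 3 thus holds the second highest of the three numbers: its nearest neighbour is compound 2, within the scatter, while compound 1 lies furthest away with a lower number beyond the scatter. Compound 4 `C1=C(CCN2CCN(c3cccc4c3OCCO4)CC2)Cc2ccccc21` has not yet been measured; it differs from compound 3 by a group of 9 heavy atoms (9 carbon; one five-membered non-aromatic ring of carbon only, one six-membered aromatic ring of carbon only) in place of a group of 9 heavy atoms (9 carbon; one five-membered non-aromatic ring of carbon only, one six-membered aromatic ring of carbon only), on a saturated chain carbon, two bonds along the chain from an amine nitrogen in a ring. For the measured compounds named here, no step between measured compounds matches this change, so in this assay a step within the scatter, in no particular direction, is expected. Compound 4 is estimated at 4 mg/kg, with a range from 1.5 mg/kg to 10 mg/kg. The expected step is a 1.0-fold lower number from compound 3 to compound 4 (0.00 log units; within the scatter).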

Compound 4, dose for half-maximal effect: 0.17 mg/kg
The estimate for compound 4 lay 24-fold (1.37 log units) above the measured number; the whole stated range lies above it.
By their numbers in this assay, from the lowest: compound 4; then compound 1; then compounds 3 and 2 (each within the scatter of the next).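

Swapping 2,3-dihydro-1H-inden-1-yl for a group of equal heavy-atom count with one double bond outside aromatic rings, on a saturated chain carbon, two bonds along the chain from an amine nitrogen in a ring, gives a 24-fold lower number from compound 3 to compound 4 (1.37 log units; beyond the scatter) in this assay. For the compounds shown here, the earlier compounds offered no single-place step, so this is the first to show that this position can respond strongly to such a change. Nothing available explains the shift. On these data alone, whether a longer chain or a methyl group on the double bond would preserve this low number remains open.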